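A few compounds are considered here, and "the series" means these few. Any claim that something is new, unique, unknown or untested is made for them only; others in the source may bear on it.

Compound 1 `C#CCNC1CCc2c(SCCc3ccc(Br)cc3)cccc21`: 85300 nM
Compound 2 `C#CCNC1CCc2c(OCc3cccc(C(F)(F)F)c3)cccc21`: 6410 nM
Compound 3 `C#CCNC1CCc2c(SCc3cccc(C)c3)cccc21`: a limit of the assay, > 100000 nM

In an assay on isolated protein for inhibition of Amine oxidase [flavin-containing] B (Homo sapiens) (on this read-out lower numbers stand for stronger inhibition and higher numbers for weaker inhibition), compound 1 gives 85300 nM, the higher of the two numbers shown, while compound 2 gives 6410 nM, a lower number by a gap beyond the scatter. Compound 3 reaches only the limit of > 100000 nM in this assay, at which 1 of the 3 values shown sits, and so yields no number. Compound 4 `C#CCNC1CCc2c(SCCc3ccc(Cl)cc3)cccc21` differs from compound 1 by chloro in place of bromo on an aromatic carbon. No step of this kind between measured compounds is shown, so the expectation rests on compound 1 alone. The step from compound 1 to compound 4 is expected to be a 1.1-fold higher number from compound 1 to compound 4 (0.02 log units; within the scatter), not beyond the scatter. Compound 4 is therefore estimated at 90000 nM, with a range from 40000 nM to 200000 nM.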

Compound 4, half-maximal inhibitory concentration: 10800 nM
Estimate against measurement, compound 4: 8.3-fold (0.92 log units) above; measured number outside the range, below it.
By their numbers in this assay, from the lowest: compounds 2 and 4 (each within the scatter of the next); then compound 1. At a limit, above all of these: compound 3.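

The position on the aromatic carbon, para to a large group, proves sensitive to the halogen: in this assay chloro in place of bromo, one heavy atom for another, gives a 7.9-fold lower number from compound 1 to compound 4 (0.90 log units; beyond the scatter) on this chain. So the 4-bromophenyl to 4-chlorophenyl change is not neutral here, even though it adds no ring, donor, acceptor or charge. Nothing shown here accounts for the size of this step.

On these data alone, whether fluoro, methyl or methoxy at this position would continue the trend remains open. So does whether the same halogen change would act alike with the oxygen linker in place of sulfur.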